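The compounds below may be only part of what the source reports. "The series", "measured", "known", "first", "only" and "open" are said of these compounds alone.

Within the data shown here, in a functional assay on A-375 cells (Homo sapiens) for cytotoxicity, read by MTT assay, with a stated time of 72 h (a lower number here means a stronger inhibitor, a higher number a weaker inhibitor), three compounds sharing one core have numbers so far. Compound 2 `O=C1c2c[n+]([O-])c3ccccc3c2C(=O)c2c1c1ccccc1n2Cc1cn([C@@H]2C[C@H](O)[C@@H](CO)O2)nn1` stands lowest at 20 nM, compared with compound 1 `O=C1c2c[n+]([O-])c3ccccc3c2C(=O)c2c1c1ccccc1n2CCCCn1ccnc1` at 350 nM and compound 3 `CCCCN1CCN(CCCCn2c3c(c4ccccc42)C(=O)c2c[n+]([O-])c4ccccc4c2C3=O)CC1` at 2150 nM. Compound 4 `CC1(C)OC[C@@H](Cn2cc(Cn3c4c(c5ccccc53)C(=O)c3c[n+]([O-])c5ccccc5c3C4=O)nn2)O1` differs from compound 2 in one place, on an aromatic nitrogen of a five-membered aromatic ring with 3 nitrogen: (2,2-dimethyl-1,3-dioxolan-4-yl)methyl in place of 4-hydroxy-5-(hydroxymethyl)oxolan-2-yl ((2,2-dimethyl-1,3-dioxolan-4-yl)methyl in place of 4-hydroxy-5-(hydroxymethyl)oxolan-2-yl on an aromatic nitrogen). Among the measured compounds shown here, no measured pair shows this swap. For the measured compounds named here, the only measured single-place change is a 6.1-fold higher number from compound 1 to compound 3 (0.79 log units; beyond the scatter), which exchanged other groups on a saturated chain, so it is a rough guide to size only. It does show that changing one terminal group in this series can move the number beyond the scatter. Compound 2 holds the lowest of the three values at 20 nM, so a move upward, toward a weaker inhibitor, seems the likelier direction. The expected change is a 4.0-fold higher number from compound 2 to compound 4 (0.60 log units; beyond the scatter), somewhat smaller than the measured step. For compound 4 the estimated value is 80 nM, with an expected range from 20 nM to 350 nM.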

Compound 4, half-maximal inhibitory concentration: 450 nM
The estimate for compound 4 lay 5.6-fold (0.75 log units) below the measured number, outside the stated range (above it).
By their numbers in this assay, from the lowest: compound 2; then compounds 1 and 4 (each within the scatter of the next); then compound 3.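

In this assay, the step of a 23-fold higher number from compound 2 to compound 4 (1.35 log units; beyond the scatter) shows that the group on the aromatic nitrogen of the five-membered ring strongly affects the number, whereas the earlier step concerned only a saturated chain. The two groups have the same count of 8 heavy atoms, so heavy-atom count alone does not track the change. They still differ in several ways at once: 4-hydroxy-5-(hydroxymethyl)oxolan-2-yl has 2 hydrogen-bond donors and 3 defined stereocentres, against 0 and 1 for (2,2-dimethyl-1,3-dioxolan-4-yl)methyl, and no measurement here explains the step.

The compounds shown therefore leave open which of these differences matters. A 2,3-dihydroxypropyl group or a plain butyl chain on the same nitrogen would help separate the contribution of the hydroxyl groups from that of the ring.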